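This account rests on a few compounds, and the source may have more. Where it says the series, first, only, none or still open, it means among the compounds named here.

Measured in a functional assay on CHO cells with adenosine receptor A1 (Homo sapiens) as the target, read by cAMP accumulation and immunoassay, with a stated time of 6 min, tested at 1 uM; a lower number here means a stronger effect, a higher number a weaker effect of the compound at the concentration tested:
compound 1 `Nc1scc(CN2CCN(c3cc(Cl)cc(Cl)c3)CC2)c1C(=O)c1ccc(Cl)cc1`, -69%
compound 2 `COc1ccc(N2CCN(Cc3csc(N)c3C(=O)c3ccc(Cl)cc3)CC2)cc1`, -15%

Among the compounds with values here, compound 2 stands highest of the two numbers in this assay; its nearest neighbour is compound 1, the only measured step being a number 54 percentage points higher from compound 1 to compound 2 (beyond the scatter). Compound 3 `Nc1scc(CN2CCN(c3cccc(C(F)(F)F)c3)CC2)c1C(=O)c1ccc(Cl)cc1` carries 3-(trifluoromethyl)phenyl in place of 4-methoxyphenyl on an amine nitrogen in a ring. Within the data shown here, the change sits at the same ring nitrogen as the one measured step, so that step bears on it; the entering group is neither of the two measured groups, and the direction is therefore uncertain. A partial return toward compound 1 is expected, so the step from compound 2 to compound 3 is estimated as a number 30 percentage points lower from compound 2 to compound 3 (beyond the scatter). Compound 3 is expected to give -45% in this assay, within -78% to -8%.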

Compound 3, a percentage reported as activity, at one concentration (the size of the read-out at that concentration, not a potency): -72%
Estimate against measurement, compound 3: 27 percentage points above; the range from low to high includes it.
By their numbers in this assay, from the lowest: compounds 3 and 1 (each within the scatter of the next); then compound 2.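

Replacing 4-methoxyphenyl with 3-(trifluoromethyl)phenyl on the ring nitrogen in this assay gives a number 57 percentage points lower from compound 2 to compound 3 (beyond the scatter). Against the 3,5-dichlorophenyl group, the same 3-(trifluoromethyl)phenyl group gives a number 3 percentage points lower from compound 1 to compound 3 (within the scatter), so the low number is not confined to 3,5-dichlorophenyl, while the 4-methoxyphenyl of compound 2 goes against any shared reading of these aryl groups. No available evidence gives a cause for these steps. The compounds shown leave open whether the methoxy group itself or its place on the phenyl ring sets the higher number of compound 2. A 3-methoxyphenyl or a 4-(trifluoromethyl)phenyl group on this nitrogen would separate the two.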